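The source may hold more compounds than are shown below. What is called first, only, known or untested is meant among the compounds shown, and "the series" means these compounds.

The series shares one core, seen in compound 1 `O=C(CSc1nc(Nc2ccccc2)c2ccccc2n1)Nc1ccccc1Br`, compound 2 `COc1cccc(NC(=O)CSc2nc(Nc3ccccc3)c3ccccc3n2)c1` and compound 3 `C=CC(=O)Nc1cccc(NC(=O)CSc2nc(Nc3cccc(F)c3)c3ccccc3n2)c1`. In a functional assay on PC-3 cells (Homo sapiens) for inhibition, read by MTT assay, with a stated time of 72 h (on this read-out lower numbers stand for stronger inhibition and higher numbers for weaker inhibition), compound 1 gives 19800 nM. In this assay, among the compounds with values here, compound 2 gives 11600 nM; the only single-point step among the measured compounds, a 1.7-fold lower number from compound 1 to compound 2 (0.23 log units; within the scatter), sits at the amide-type nitrogen. Compound 3 gives 5370 nM in this assay, the lowest of the three numbers; compound 2 stands nearest to it and compound 1 furthest, and both gaps lie beyond the scatter.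

Compound 4 `C=CC(=O)Nc1cccc(NC(=O)CSc2nc(Nc3ccc(CC)cc3)c3ccccc3n2)c1` differs from compound 3 in one place: 4-ethylphenyl in place of 3-fluorophenyl on a nitrogen on an aromatic ring. Within the data shown here, no measured step touches this nitrogen on an aromatic ring. Among the measured compounds shown here, the one step that is known, a 1.7-fold lower number from compound 1 to compound 2 (0.23 log units; within the scatter), concerns a different nitrogen and was itself within the scatter. Nothing in the measured compounds therefore shows how a 4-ethylphenyl in place of a 3-fluorophenyl at this position moves the number, and the expectation is no step beyond the scatter, a 1.1-fold higher number from compound 3 to compound 4 (0.05 log units; within the scatter). Compound 4 is accordingly estimated at 6000 nM in this assay, with a range from 2500 nM to 15000 nM.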

Compound 4, half-maximal inhibitory concentration: 24300 nM
Compound 4: middle estimate off by 4.1-fold (0.61 log units), on the low side; the whole stated range lies below it.
By their numbers in this assay, from the lowest: compound 3; then compounds 2, 1 and 4 (each within the scatter of the next, the first and the last beyond it).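

The aryl group on this nitrogen proves not to be a silent part of the series: in this assay, 4-ethylphenyl in place of 3-fluorophenyl gives a 4.5-fold higher number from compound 3 to compound 4 (0.66 log units; beyond the scatter), the only single-place step beyond the scatter among the compounds shown. The change swaps one carbon-only aromatic ring for another, and neither group carries a hydrogen-bond donor, a hydrogen-bond acceptor or a net charge, so the step appears without any change in those counts. No measurement here accounts for the step, and the reason for it remains unknown.

The compounds shown do not separate the loss of the fluorine from the gain of the ethyl, nor the identity of the substituent from its place on the ring, as the two names differ in both. They also leave open how an amine, a carboxylic acid or a longer chain such as butyl on this aromatic ring would read, and whether the same change would give a similar step with 2-bromophenyl or 3-methoxyphenyl on the amide-type nitrogen.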